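A few compounds are considered here, and "the series" means these few. Any claim that something is new, unique, unknown or untested is made for them only; others in the source may bear on it.

Measured compounds:
compound 1, `CC(=O)O[C@@H]1OC(=O)[C@](C)(C(C)=O)[C@@H]1C`, giving 7000 nM
compound 2, `CC(=O)CC[C@]1(C(C)=O)C(=O)O[C@@H](OC(C)=O)[C@H]1C`, giving 8000 nM

Both numbers come from a functional assay on DA-3 cells for cytotoxicity against DA-3 cell line (Mus musculus), read by MTT assay; on this read-out lower numbers stand for stronger inhibition and higher numbers for weaker inhibition. Compound 1 has the lower of the two numbers, but its nearest neighbour, compound 2, sits only a 1.1-fold higher number from compound 1 to compound 2 (0.06 log units; within the scatter) away, so the two compounds are not distinguished by this assay. That single step is the only one known: a 2-oxopropyl in place of hydrogen on a saturated chain carbon bound to a saturated ring carbon left the number essentially unchanged.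

Compound 3, `CC(=O)O[C@@H]1OC(=O)[C@](Br)(C(C)=O)[C@@H]1C`, has not yet been measured. Its difference from compound 1 is bromo in place of methyl on a saturated ring carbon. Among the compounds with values here, no measured step touches this position of the shared core, and the one step that exists concerns a different carbon, so it offers no direct guide. What it does show is that the core of compound 1 tolerated a change without the number moving beyond the scatter. On that basis the expectation for compound 3 in this assay is a step of about a 1.4-fold lower number from compound 1 to compound 3 (0.15 log units; within the scatter), which is a modest shift toward a lower number, not a large one. Compound 3 is therefore estimated at 5000 nM, with a range from 1500 nM to 20000 nM.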

Compound 3, half-maximal inhibitory concentration: 6000 nM
Estimate against measurement, compound 3: 1.2-fold (0.08 log units) below; the range from low to high includes it.
By their numbers in this assay, from the lowest: compounds 3, 1 and 2 (each within the scatter of the next).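

In this assay, within the data shown here, bromo in place of methyl on this saturated ring carbon gives a 1.2-fold lower number from compound 1 to compound 3 (0.07 log units; within the scatter) and so shows for the first time that this position of the shared core can change from a carbon group to a halogen without the number leaving the scatter. The same carbon carries the much longer 2-acetylethyl group in compound 2, and bromo in its place gives a 1.3-fold lower number from compound 2 to compound 3 (0.12 log units; within the scatter) so that methyl, 2-acetylethyl and bromo, three quite different groups on one carbon, cannot be told apart in this read-out. No supporting measurement is available to explain this result.

Still open, as far as these compounds go, is whether a group of another kind on this carbon, such as an amine or a carboxylic acid, would move the number beyond the scatter. From the compounds shown here alone, the acetoxy group on the ring is the same in all three compounds, so the effect of replacing it, for example with a hydroxyl group, also remains unknown.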